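Series notes: methyl in place of hydrogen on the core

The compounds below may be only part of what the source reports. "The series", "measured", "known", "first", "only" and "open" are said of these compounds alone.

Going by the values given here, compound 2 `O=C(O)c1cc2cc(Cn3ccnc3)ccc2s1` gives 21 nM in an assay for inhibition of Thromboxane-A synthase (Homo sapiens) (a higher number here means a weaker inhibitor, a lower number a stronger inhibitor), the lowest of the two numbers so far, while compound 1 `O=C(O)c1cc2cc(Cn3ccnc3)ccc2o1` gives 34 nM, within the scatter of that. Compound 3 `Cc1c(C(=O)O)sc2ccc(Cn3ccnc3)cc12` differs from compound 2 by methyl in place of hydrogen on an aromatic carbon. Among the compounds with values here, no step between measured compounds covers this change, so the expectation is for no movement beyond the scatter, in either direction. Compound 3 is therefore estimated at 25 nM, with a range of 8 nM to 80 nM. The expected step is a 1.2-fold higher number from compound 2 to compound 3 (0.08 log units; within the scatter).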

Compound 3, half-maximal inhibitory concentration: 29 nM
The estimate for compound 3 lay 1.2-fold (0.06 log units) below the measured number, within the range that was stated.
By their numbers in this assay, from the lowest: compounds 2, 3 and 1 (each within the scatter of the next).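

In this assay methyl in place of hydrogen on an aromatic carbon gives a 1.4-fold higher number from compound 2 to compound 3 (0.14 log units; within the scatter) at this place on the five-membered aromatic ring with 1 sulfur. The position next to the ring atom that bears a carboxy group therefore accepts a methyl without a step beyond the scatter, though this rests on a single pair. No further data on hand bear on this result.

As far as these compounds go, whether a longer chain or an amine at this place would also stay within the scatter remains open. Also open, from the compounds shown here alone, is whether methyl on the core of compound 1 would behave the same way.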